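Benzyl for tert-butyl ester on the thiophen-3-yl analogue

The source may report more compounds than this note shows. Statements on the series, on what has been measured and on what is new or still open speak of the compounds shown alone.

Three compounds of the series have numbers in an assay on membranes from HeLa cells for displacement of a labelled ligand from adenosine receptor A3 (Homo sapiens), read by scintillation counting, with a stated time of 180 min, tested at 1 uM; on this read-out lower numbers stand for less inhibition and higher numbers for more inhibition at the one concentration tested (going by the name of the read-out). Compound 1 `CC1=C(C(=O)OC(C)(C)C)C(c2cccs2)NC(=O)N1` gives 7% in this assay. Compound 2 `CC1=C(C(=O)OCc2ccccc2)C(c2cccs2)NC(=O)N1` gives 8%. Compound 3 `CC1=C(C(=O)OC(C)(C)C)C(c2ccsc2)NC(=O)N1` gives 1%, the lowest of the three, though both gaps to it lie within the scatter.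

The change benzyl in place of tert-butyl on an oxygen next to a carbonyl group made the step of a number 1 percentage points higher from compound 1 to compound 2 (within the scatter). The change thiophen-3-yl in place of thiophen-2-yl on a saturated ring carbon made the step of a number 6 percentage points lower from compound 1 to compound 3 (within the scatter). Neither step rises above the scatter, so no order among compound 1, compound 2 and compound 3 can be read from these numbers.

Compound 4 `CC1=C(C(=O)OCc2ccccc2)C(c2ccsc2)NC(=O)N1` is not yet measured. It differs from compound 3 by benzyl in place of tert-butyl on an oxygen next to a carbonyl group, and the two cores differ by the thiophene swap already told between compound 1 and compound 3. The place of the ester change reads the same in both pairs, so this is the same change as from compound 1 to compound 2.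

For compound 4 the expected step is a number 1 percentage points higher from compound 3 to compound 4 (within the scatter) in this assay, resting on the measured step of a number 1 percentage points higher from compound 1 to compound 2 (within the scatter) and on the value of compound 3, 1%. Compound 4 is therefore estimated at 2% in this assay, with a likely range from -8% to 12%.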

Compound 4, a percentage reported as inhibition, at one concentration (the size of the read-out at that concentration, not a potency): 25%
The estimate for compound 4 lay 23 percentage points below the measured number; the whole stated range lies below it.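

In this assay the benzyl-for-tert-butyl ester change gave a number 24 percentage points higher from compound 3 to compound 4 (beyond the scatter), so the near-absent effect seen on the thiophen-2-yl core does not carry over to the thiophen-3-yl core: the same change on two cores in this assay, a number 1 percentage points higher (within the scatter) from compound 1 to compound 2 and a number 24 percentage points higher (beyond the scatter) from compound 3 to compound 4, 23 percentage points apart, beyond the scatter of two such steps

Read the other way, the thiophene swap gave a number 17 percentage points higher from compound 2 to compound 4 (beyond the scatter) among the benzyl esters, which does not match its step among the tert-butyl esters: the same change on two cores in this assay, a number 6 percentage points lower (within the scatter) from compound 1 to compound 3 and a number 17 percentage points higher (beyond the scatter) from compound 2 to compound 4, 23 percentage points apart, beyond the scatter of two such steps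

The two changes therefore cannot be added together in this set, but the finding rests on a single group of four compounds tested at one concentration, gives no potency, and does not show why the combination in compound 4 stands apart.

Open, going by these compounds, is whether the effect needs benzyl itself or would also appear with a methyl ester, a longer chain on the oxygen or a carboxylic acid. Also open, on these data alone, is whether a phenyl or furan-2-yl group in place of the thiophene would pair with the benzyl ester in the same way.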